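Notes on the step from compound 3 to compound 4

This account rests on a few compounds, and the source may have more. Where it says the series, first, only, none or still open, it means among the compounds named here.

In a functional assay on HeLa cells (Homo sapiens) for cytotoxicity, read by MTT assay, with a stated time of 24 h (on this read-out higher numbers stand for weaker inhibition and lower numbers for stronger inhibition), compound 1 `CN1C/C(=C\c2cccc([N+](=O)[O-])c2)C(=O)/C(=C/c2ccccc2F)C1` gives 2340 nM, compound 2 `CN1C/C(=C\c2ccc(Br)cc2)C(=O)/C(=C/c2cccc([N+](=O)[O-])c2)C1` gives 11900 nM and compound 3 `CN1C/C(=C\c2cccc([N+](=O)[O-])c2)C(=O)/C(=C/c2ccc(Cl)c(Cl)c2)C1` gives 9120 nM. That last value is placed by two steps: a 1.3-fold lower number from compound 2 to compound 3 (0.12 log units; within the scatter), and a 3.9-fold higher number from compound 1 to compound 3 (0.59 log units; beyond the scatter). Compound 4 `CN1C/C(=C\c2cccc(Br)c2)C(=O)/C(=C/c2cccc([N+](=O)[O-])c2)C1` carries 3-bromophenyl in place of 3,4-dichlorophenyl, on a double-bonded chain carbon bound to a double-bonded ring carbon: 3-bromophenyl in place of 3,4-dichlorophenyl on a double-bonded chain carbon bound to a double-bonded ring carbon. The closest measured exchange, between 4-bromophenyl and 3,4-dichlorophenyl, is the small step above. Going by the values given here, the larger steps, a 5.1-fold higher number from compound 1 to compound 2 (0.71 log units; beyond the scatter) and the one to compound 3, both leave 2-fluorophenyl, which this change does not involve. No step beyond the scatter is therefore expected in this assay, and the expected change is a 1.2-fold lower number from compound 3 to compound 4 (0.08 log units; within the scatter). Compound 4 is estimated at 7500 nM, with an expected range of 3000 nM to 17000 nM.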

Compound 4, half-maximal inhibitory concentration: 11100 nM
Estimate against measurement, compound 4: 1.5-fold (0.17 log units) below; the range from low to high includes it.
By their numbers in this assay, from the lowest: compound 1; then compounds 3, 4 and 2 (each within the scatter of the next).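

In this assay, 3-bromophenyl in place of 3,4-dichlorophenyl gives a 1.2-fold higher number from compound 3 to compound 4 (0.09 log units; within the scatter), and 3-bromophenyl in place of 4-bromophenyl gives a 1.1-fold lower number from compound 2 to compound 4 (0.03 log units; within the scatter), so these three groups do not separate at this place. Against 2-fluorophenyl the same group gives a 4.7-fold higher number from compound 1 to compound 4 (0.68 log units; beyond the scatter), which makes 2-fluorophenyl the only group shown that stands apart from the others. No measurement shown accounts for either the agreement or the gap.

On these data alone, it remains open whether the lower number of compound 1 belongs to fluorine or to 2-fluorophenyl as a whole. Phenyl groups carrying an amine or a carboxylic acid are not among the compounds shown, so the series says nothing about them.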